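This account rests on a few compounds, and the source may have more. Where it says the series, first, only, none or still open, it means among the compounds named here.

Three compounds have been measured in a functional assay on A549 cells (Homo sapiens) for cytotoxicity, read by MTT assay, with a stated time of 72 h; a higher number here means that more compound is needed for the effect, a lower number that less compound is needed:

Compound 1 `CCCCCc1cc(Nc2ccc(OC)cc2)cc(=O)o1`: 4.42 uM
Compound 2 `COc1ccc(Nc2cc(/C=C/c3ccccc3)oc(=O)c2)cc1`: 0.11 uM
Compound 3 `COc1ccc(Nc2cc(-c3ccco3)oc(=O)c2)cc1`: 1.91 uM

Compound 3 holds the second highest number of the three in this assay. Its nearest neighbour is compound 1, and the step of a 2.3-fold lower number from compound 1 to compound 3 (0.36 log units; beyond the scatter) is modest; the step of a 17-fold higher number from compound 2 to compound 3 (1.24 log units; beyond the scatter) is large, so compound 2 lies far from it on the other side.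

Compound 4 `COc1ccc(Nc2cc(C(C)C)oc(=O)c2)cc1` differs from compound 3 in one place: isopropyl in place of furan-2-yl on an aromatic carbon. Going by the values given here, no measured step exchanges furan-2-yl for isopropyl directly. The step that bears most on it is a 2.3-fold lower number from compound 1 to compound 3 (0.36 log units; beyond the scatter), in which the pentyl chain of compound 1 gave way to furan-2-yl; compound 1 carries an unbranched alkyl chain at the same place where compound 4 carries isopropyl, and is therefore the closest guide. Among the compounds with values here, the large step of a 17-fold higher number from compound 2 to compound 3 (1.24 log units; beyond the scatter) shows how much this position can move the number, but the 2-phenylethenyl group of compound 2 has no counterpart in compound 4. Compound 4 is therefore expected to land near compound 1, a modest rise a 2.6-fold higher number from compound 3 to compound 4 (0.42 log units; beyond the scatter) in this assay, roughly reversing the earlier change. The expected value for compound 4 is 5 uM, with a range from 1.8 uM to 15 uM.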

Compound 4, concentration for half-maximal effect: > 30 uM
Compound 4: only a limit was reported; the forecaster's own chance of this, stated with the estimate: 5%; middle value at least 6.0-fold (0.77 log units) away from the limit.
By their numbers in this assay, from the lowest: compound 2; then compound 3; then compound 1. At a limit, above all of these: compound 4.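

In this assay, compound 4 gives only a limit, not a number: the limit of > 30 uM in this assay, at which 1 of the 4 values shown sits.

Even so, the steps can be read as lower bounds, and they show that this position is more sensitive than the earlier compounds suggested: an at least 15-fold higher number from compound 3 to compound 4 (1.19 log units; beyond the scatter) is large, an at least 270-fold higher number from compound 2 to compound 4 (2.43 log units; beyond the scatter) is larger still, and an at least 6.7-fold higher number from compound 1 to compound 4 (0.83 log units; beyond the scatter) separates two alkyl groups. Going by these compounds alone, until now the only alkyl group at this place was the pentyl chain of compound 1, which stood a modest step from the furan-2-yl of compound 3, so the new result shows that an alkyl group here does not by itself fix the number, since isopropyl and pentyl lie apart beyond the scatter.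

The four compounds cannot separate the loss of the five-membered aromatic ring from the branching of the chain, and an unbranched propyl chain, a tert-butyl group or a phenyl ring at this place would bear on that question. They also leave open how far the true number of compound 4 lies past its limit, and so how large these steps really are.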